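Removing the methoxymethyl ether from the diethylamino carbamate

A few compounds are considered here, and "the series" means these few. Any claim that something is new, unique, unknown or untested is made for them only; others in the source may bear on it.

Working notes on two carbamates carrying a tetradecyl chain and a methoxymethyl-protected oxygen. Compound 1 `CCCCCCCCCCCCCC[C@H](OCOC)[C@H](CN(CC)CC)NC(=O)OC(C)(C)C` is the diethylamino member; compound 2 `CCCCCCCCCCCCCC[C@H](OCOC)[C@H](CN(CCCC)CCCC)NC(=O)OC(C)(C)C` carries dibutylamino in its place. In a functional assay on DLD-1 cells (Homo sapiens) for antiproliferative activity, read by sulforhodamine B assay, with a stated time of 48 h, tested at 10 uM (a lower number here means less inhibition, a higher number more inhibition at the concentration tested (going by the name of the read-out)), compound 1 gives 46.2%, and compound 2 gives 56.1%. Within the data shown here, the only step measured so far, a number 9.9 percentage points higher from compound 1 to compound 2 (within the scatter), is within the scatter, so compound 1 stands alongside compound 2 rather than apart from it; the amine change left the read-out essentially unchanged.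

Compound 3 `CCCCCCCCCCCCCC[C@H](O)[C@H](CN(CC)CC)NC(=O)OC(C)(C)C` keeps the diethylamino group and the carbamate of compound 1 but differs at the protected oxygen: hydrogen in place of methoxymethyl on an oxygen on a saturated carbon. The same difference, cut one bond further out, reads methoxymethoxy to hydroxy. Among the measured compounds shown here, no measured step touches this position; the one available step, from the amine, carried no information about the oxygen and was itself within the scatter. There is therefore nothing in the series to motivate a step beyond the scatter in either direction.

Compound 3 is expected to give about 46% in this assay, within 25% to 66%, an estimated step of a number 0.2 percentage points lower from compound 1 to compound 3 (within the scatter) from compound 1.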

Compound 3, a percentage reported as inhibition, at one concentration (the size of the read-out at that concentration, not a potency): 14.7%
Beside the measured number, compound 3's estimate is 31.3 percentage points above it; the whole stated range lies above it.
By their numbers in this assay, from the lowest: compound 3; then compounds 1 and 2 (each within the scatter of the next).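

In this assay, among these compounds, the oxygen on a saturated carbon is the first position where a change moves the read-out beyond the scatter: hydrogen in place of methoxymethyl gives a number 31.5 percentage points lower from compound 1 to compound 3 (beyond the scatter) on the diethylamino carbamate, while the amine exchange gives a number 9.9 percentage points higher from compound 1 to compound 2 (within the scatter) and stays within it. The methoxymethyl group on this oxygen therefore cannot be treated as a silent passenger in this read-out, and the hydroxy form shows less inhibition at the concentration tested than its methoxymethoxy counterpart. Nothing available bears on why the read-out falls with this change, so the step stands as an observation only.

Going by these compounds, the step is read on the diethylamino member alone, so whether the same exchange on the dibutylamino member of the pair gives a step of similar size remains open. Also open, on these data alone, is how other groups on this oxygen, such as methyl or acetyl, would read, and what a free amine in place of the tert-butyl carbamate would do to the hydroxy compound.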